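Adding One Carbon to the Sulfur-Bound Chain

The compounds below may be only part of what the source reports. "The series", "measured", "known", "first", "only" and "open" are said of these compounds alone.

Three compounds with a shared core were tested in a functional assay on MDA-MB-231 cells (Homo sapiens) for cytotoxicity, read by neutral red uptake, with a stated time of 72 h; a lower number here means a stronger inhibitor, a higher number a weaker inhibitor. Compound 1 `CCCCCNc1nc(SCC)nc2ncccc12` gives 1300 nM in this assay. Compound 2 `CCCCCNc1nc(SC(C)C)nc2ncccc12` differs from compound 1 by methyl in place of hydrogen on a saturated chain carbon bound to a saturated chain carbon and a sulfur, and in this assay compound 2 gives 5600 nM, so that a 4.3-fold higher number from compound 1 to compound 2 (0.63 log units; beyond the scatter). Compound 3 `CCCCCCNc1nc(SCCCC)nc2ncccc12` gives 1200 nM; the difference between the cores of compound 1 and compound 3 is not broken down here, and their two values sit close together.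

Compound 4 `CCCCCCNc1nc(SCCCCC)nc2ncccc12` has not been measured yet. It differs from compound 3 by methyl in place of hydrogen on a saturated chain carbon, four bonds along the chain from a sulfur. This is the same kind of change as that from compound 1 to compound 2, but not the same: there the methyl entered on a saturated chain carbon bound to a saturated chain carbon and a sulfur, here it enters on a saturated chain carbon four bonds along the chain from a sulfur, turning butyl into pentyl. Among the measured compounds shown here, the one measured step of this kind is modest. For compound 4 a smaller step than that is expected, estimated as a 1.3-fold higher number from compound 3 to compound 4 (0.10 log units; within the scatter), resting on compound 3 at 1200 nM and on the change falling further from the sulfur. Compound 4 is thus expected to give about 1500 nM, most likely between 600 nM and 4000 nM.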

Compound 4, half-maximal inhibitory concentration: 9000 nM
Compound 4: the middle estimate sits 6.0-fold (0.78 log units) below what was measured; measured number outside the range, above it.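

In this assay, putting a methyl in place of hydrogen on a saturated chain carbon, four bonds along the chain from a sulfur, gives a 7.5-fold higher number from compound 3 to compound 4 (0.88 log units; beyond the scatter), and the earlier step on the other core can be set beside it: the same change on two cores in this assay, a 4.3-fold higher number (0.63 log units; beyond the scatter) from compound 1 to compound 2 and a 7.5-fold higher number (0.88 log units; beyond the scatter) from compound 3 to compound 4, 1.7-fold (0.24 log units) apart, within the scatter of two such steps. Within these two pairs, then, the change carries from one core to the other: the number rises both times, and the two steps do not differ by more than repeated measurements would. Among the compounds shown here, this is no general rule, since it rests on only two pairs, the methyl enters at a different place in each, and nothing here explains why the number rises.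

The compounds shown leave open how the smaller steps along the same chain, such as ethyl to propyl or propyl to butyl, would behave on either core. They also leave open whether a chain longer than pentyl, or a chain carrying an amine or a carboxylic acid, would follow the same trend.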